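The compounds below may be only part of what the source reports. "The series", "measured", "known", "first", "only" and "open" are said of these compounds alone.

Measured compounds:
Compound 1, `O=C(NCc1ccc(S(=O)(=O)c2cncc(C(F)(F)F)c2)cc1)N1Cc2ccncc2C1`, gives 15 nM in an assay on isolated protein for inhibition of Nicotinamide phosphoribosyltransferase (Homo sapiens), read by mass spectrometry, with stated times of 15 min and 30 min; a lower number here means a stronger inhibitor, a higher number a weaker inhibitor.
Compound 2, `CCCn1cc(S(=O)(=O)c2ccc(CNC(=O)N3Cc4ccncc4C3)cc2)cn1`, gives 17 nM in this assay.
Compound 3, `CC(=O)N1CCC(S(=O)(=O)c2ccc(CNC(=O)N3Cc4ccncc4C3)cc2)CC1`, gives 83 nM in this assay.

All three share one core and differ only in the group on the sulfonyl sulfur. Compound 3 has the highest number of the three: the step of a 5.5-fold higher number from compound 1 to compound 3 (0.74 log units; beyond the scatter) and the step of a 4.9-fold higher number from compound 2 to compound 3 (0.69 log units; beyond the scatter) both go beyond the scatter, whereas the step of a 1.1-fold higher number from compound 1 to compound 2 (0.05 log units; within the scatter) stays within it.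

Compound 4, `CN1CCC(S(=O)(=O)c2ccc(CNC(=O)N3Cc4ccncc4C3)cc2)CC1`, keeps the piperidine of compound 3 and changes only its substituent: methyl in place of acetyl on an amine nitrogen in a ring. For the measured compounds named here, no measured step touches this position; every step so far swaps the whole group on the sulfonyl sulfur, so nothing here says how the amine substituent matters. Going by the values given here, with no precedent, the expectation for compound 4 is a step of modest size at most, a 1.2-fold higher number from compound 3 to compound 4 (0.08 log units; within the scatter), in either direction. Compound 4 is therefore estimated at 100 nM in this assay, with a plausible range from 35 nM to 300 nM.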

Compound 4, half-maximal inhibitory concentration: 48 nM
Compound 4: middle estimate off by 2.1-fold (0.32 log units), on the high side, within the range that was stated.
By their numbers in this assay, from the lowest: compounds 1 and 2 (each within the scatter of the next); then compounds 4 and 3 (each within the scatter of the next).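

For the compounds shown here, this is the first view of the substituent on the ring nitrogen of the piperidine: in this assay, methyl in place of acetyl gives a 1.7-fold lower number from compound 3 to compound 4 (0.24 log units; within the scatter) and so cannot be told apart from acetyl, even though the carbonyl and its hydrogen-bond acceptor are gone. The swap does not close the gap to the groups on the sulfonyl sulfur in the other compounds, since the steps of a 2.8-fold higher number from compound 2 to compound 4 (0.45 log units; beyond the scatter) and a 3.2-fold higher number from compound 1 to compound 4 (0.51 log units; beyond the scatter) remain on record for the 1-methylpiperidin-4-yl group. Nothing available explains these numbers.

The compounds shown leave open how a bare ring amine, with hydrogen on this nitrogen, or a longer chain such as propyl would behave here. Also open, on these data alone, is whether any substituent at this nitrogen can bring a piperidine level with compound 1 and compound 2.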